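The compounds below may be only part of what the source reports. "The series", "measured", "known", "first", "only" and "open" are said of these compounds alone.

Compound 1 `CCCS(=O)(=O)Nc1ccc(F)c(C(=O)c2n[nH]c3ncc(-c4ccccc4)cc23)c1F` gives 2.4% in an assay for binding affinity to dual specificity mitogen-activated protein kinase kinase 4 (Homo sapiens), read by KINOMEscan, tested at 100 nM; a lower number here means a stronger effect, a higher number a weaker effect of the compound at the concentration tested.
Compound 2 `CCCS(=O)(=O)Nc1ccc(F)c(C(=O)c2n[nH]c3ncc(-c4cccc(F)c4)cc23)c1F` gives 8.2% in this assay.
Compound 3 `CCCS(=O)(=O)Nc1ccc(F)c(C(=O)c2n[nH]c3ncc(-c4ccc(OC)cc4Cl)cc23)c1F` gives 5.3% in this assay.

Compound 3 lies in the middle of these three numbers, separated from compound 1 by a number 2.9 percentage points higher from compound 1 to compound 3 (within the scatter) and from compound 2 by a number 2.9 percentage points lower from compound 2 to compound 3 (within the scatter). Compound 4 `CCCS(=O)(=O)Nc1ccc(F)c(C(=O)c2n[nH]c3ncc(-c4ccc(S(N)(=O)=O)cc4C)cc23)c1F` carries 2-methyl-4-sulfamoylphenyl in place of 2-chloro-4-methoxyphenyl on an aromatic carbon. Within the data shown here, the steps that bear on this are the three exchanges already made on that same aromatic carbon: a number 5.8 percentage points higher from compound 1 to compound 2 (within the scatter), a number 2.9 percentage points higher from compound 1 to compound 3 (within the scatter) and a number 2.9 percentage points lower from compound 2 to compound 3 (within the scatter), none of them reaching beyond the scatter. The entering group is of a kind not represented among the measured compounds, so a somewhat wider range is allowed, but no step beyond the scatter is expected in this assay. Compound 4 is expected to give 6%, between 1.5% and 18%. For compound 4 this amounts to an expected step of a number 0.7 percentage points higher from compound 3 to compound 4 (within the scatter).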

Compound 4, a percentage reported as activity, at one concentration (the size of the read-out at that concentration, not a potency): 3.1%
Estimate against measurement, compound 4: 2.9 percentage points above, and the stated range covers the measured number.
By their numbers in this assay, from the lowest: compounds 1, 4, 3 and 2 (each within the scatter of the next).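

In this assay, 2-methyl-4-sulfamoylphenyl on this aromatic carbon stays within the scatter of all three earlier groups (a number 2.2 percentage points lower from compound 3 to compound 4 (within the scatter); a number 5.1 percentage points lower from compound 2 to compound 4 (within the scatter); a number 0.7 percentage points higher from compound 1 to compound 4 (within the scatter)). Among these compounds, the result extends what the earlier compounds showed to a sulfamoyl group, a kind of group absent from them, with no step beyond the scatter at this position. Nothing available explains this result. The compounds shown leave open whether an amine or a carboxylic acid on this carbon would also stay within the scatter. They also leave open whether a 4-sulfamoylphenyl group without the methyl would do so.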